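This account rests on a few compounds, and the source may have more. Where it says the series, first, only, none or still open, it means among the compounds named here.

Compound 1, `COc1ccc(F)cc1CNCCCNc1ccnc2cc(Cc3ccc(F)cc3Cl)ccc12`: 2460 nM
Compound 2, `Fc1ccc(Cc2ccc3c(NCCCNCc4ccco4)ccnc3c2)c(Cl)c1`: 5730 nM
Compound 3, `COc1cccc(CNCCCNc2ccnc3cc(-c4cc(C(F)(F)F)cc(C(F)(F)F)c4)ccc23)c1O`: 940 nM

Of the compounds shown here, three sharing the same core have been measured in an ADME assay on HepG2 cells (Homo sapiens) for cytotoxicity, read by luminescence, CellTiter-Glo and ATP content, with a stated time of 72 h; on this read-out lower numbers stand for an effect already at smaller amounts and higher numbers for an effect only at larger amounts of compound. Compound 1 gives 2460 nM, the second highest of the three numbers: its nearest neighbour is compound 2 with 5730 nM, and the furthest is compound 3 with 940 nM. For the measured compounds named here, only one pair among them differs in a single place, and that step is a 2.3-fold higher number from compound 1 to compound 2 (0.37 log units; beyond the scatter), a modest rise.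

The unmeasured compound 4 is `COc1ccc(F)cc1CNCCCNc1ccnc2cc(CC(C)C)ccc12`. It differs from compound 1 in one place: isopropyl in place of 2-chloro-4-fluorophenyl on a saturated chain carbon bound to an aromatic carbon. This is not the place that changes between compound 1 and compound 2, which concerns the group on a saturated chain carbon bound to an amine nitrogen, and compound 3 differs from compound 1 in more than one place. Going by the values given here, no measured step therefore speaks directly to the change toward compound 4. What the data do show is that single changes within this set have moved the read-out only modestly, so the expectation for compound 4 is a number close to that of compound 1, with the direction left open and a range wide enough to hold a step of the size already seen. Compound 4 is expected to give 3500 nM, within 1200 nM to 12000 nM, which would amount to an expected 1.4-fold higher number from compound 1 to compound 4 (0.15 log units; within the scatter).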

Compound 4, half-maximal effective concentration: 2900 nM
For compound 4 the middle estimate is 1.2-fold (0.08 log units) above the measured one; the range from low to high includes it.
By their numbers in this assay, from the lowest: compound 3; then compounds 1, 4 and 2 (each within the scatter of the next, the first and the last beyond it).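

In this assay, for the compounds shown here, the one step at this position reads a 1.2-fold higher number from compound 1 to compound 4 (0.07 log units; within the scatter) and so gives no measurable difference between the two compounds. Going by these compounds alone, until now, the only single-place step concerned the group on a saturated chain carbon bound to an amine nitrogen, so this position had no reading of its own. Here, on a saturated chain carbon bound to an aromatic carbon, the 2-chloro-4-fluorophenyl group, with its 8 heavy atoms and aromatic ring, is exchanged for isopropyl, with 3 heavy atoms and no ring, and the cell read-out of the pair stays within the usual scatter. Nothing at hand offers an explanation for this result.

A single pair cannot tell whether other groups at this place would behave the same way, such as a primary amine, a carboxylic acid or a longer chain like n-octyl. It also remains open whether isopropyl would give a similar result alongside the furan-2-yl group of compound 2, since that combination lies outside the compounds shown here.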